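The compounds below may be only part of what the source reports. "The series", "measured", "known", "first", "only" and "open" are said of these compounds alone.

Measured so far in an assay on mitochondria from L6 cells (Rattus norvegicus) for activation, with a stated time of 90 min; a lower number here means that less compound is needed, a higher number that more compound is needed for the effect:

Compound 1 `Fc1ccccc1Nc1nc2nonc2nc1Nc1cccc(F)c1F`: 500 nM
Compound 2 `Fc1ccc(Nc2nc3nonc3nc2Nc2ccccc2F)c(F)c1`: 300 nM
Compound 3 `CCOc1cccc(Nc2nc3nonc3nc2Nc2ccccc2F)c1`: 2200 nM

Compound 3 gives the highest number of the three; the two steps that lead up to it are a 4.4-fold higher number from compound 1 to compound 3 (0.64 log units; beyond the scatter) and a 7.3-fold higher number from compound 2 to compound 3 (0.87 log units; beyond the scatter), both beyond the scatter. Compound 1 and compound 2 lie within the scatter of each other, a 1.7-fold lower number from compound 1 to compound 2 (0.22 log units; within the scatter).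

Compound 4 `CCOc1ccc(Nc2nc3nonc3nc2Nc2ccccc2F)cc1` has not been measured. It differs from compound 3 only in 4-ethoxyphenyl in place of 3-ethoxyphenyl on a nitrogen on an aromatic ring. Among the measured compounds shown here, no measured step moves the ethoxy group around the ring; the only comparable step, a shift of fluorine on the same nitrogen, is a 1.7-fold lower number from compound 1 to compound 2 (0.22 log units; within the scatter), within the scatter. The steps of a 4.4-fold higher number from compound 1 to compound 3 (0.64 log units; beyond the scatter) and a 7.3-fold higher number from compound 2 to compound 3 (0.87 log units; beyond the scatter) replace difluorophenyl by 3-ethoxyphenyl and say nothing about where the ethoxy sits. The expectation for compound 4 is therefore a number near that of compound 3, with no step beyond the scatter in either direction, a 1.1-fold lower number from compound 3 to compound 4 (0.04 log units; within the scatter). Compound 4 is estimated at 2000 nM, within 700 nM to 6000 nM.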

Compound 4, half-maximal effective concentration: 3800 nM
For compound 4 the middle estimate is 1.9-fold (0.28 log units) below the measured one; measured number inside the range.
By their numbers in this assay, from the lowest: compounds 2 and 1 (each within the scatter of the next); then compounds 3 and 4 (each within the scatter of the next).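

Moving the ethoxy group, from 3-ethoxyphenyl to 4-ethoxyphenyl on the same nitrogen, is the first such shift in the series, and in this assay it gives a 1.7-fold higher number from compound 3 to compound 4 (0.24 log units; within the scatter) so the two placements cannot be told apart. Compound 4 also stays clearly separate from the difluorophenyl compounds, with a 13-fold higher number from compound 2 to compound 4 (1.10 log units; beyond the scatter) and a 7.6-fold higher number from compound 1 to compound 4 (0.88 log units; beyond the scatter) so among these four compounds the higher numbers go with ethoxyphenyl in both placements, and no compound goes against this. Nothing available explains this separation.

On these data alone, it remains open whether the higher numbers belong to ethoxy itself or would also appear with methoxy, a longer chain such as butoxy, or an amine in its place. As far as these compounds go, the role of the other aromatic group on the shared core also remains open, as it is identical in all four compounds.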